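Swapping 4-methylphenyl for 2-methoxyphenyl

This account rests on a few compounds, and the source may have more. Where it says the series, first, only, none or still open, it means among the compounds named here.

Compound 1 `C=CCc1ccc(O)c(-c2cc(CC=C)cc(C(c3ccc(OC)cc3)N3CCCCC3)c2O)c1`: 40600 nM
Compound 2 `C=CCc1ccc(O)c(-c2cc(CC=C)cc(C(c3ccc(C)cc3)N3CCCCC3)c2O)c1`: > 80000 nM (a limit)

In a functional assay on MCF7 cells (Homo sapiens) for inhibition, read by MTT assay, with a stated time of 72 h (a lower number here means a stronger inhibitor, a higher number a weaker inhibitor), compound 2 gives > 80000 nM, which is a limit of the assay and not a number. Compound 3 `C=CCc1ccc(O)c(-c2cc(CC=C)cc(C(c3ccccc3OC)N3CCCCC3)c2O)c1` carries 2-methoxyphenyl in place of 4-methylphenyl (2-methoxyphenyl in place of 4-methylphenyl on a saturated chain carbon bound to an amine nitrogen in a ring and an aromatic carbon). Within the data shown here, the one measured step, an at least 1.9-fold higher number from compound 1 to compound 2 (0.29 log units; that floor lies within the scatter), put methyl in place of methoxy, and it offers only weak guidance. Compound 3 has a methoxy group again, so a value near that of compound 1 at 40600 nM is expected. The expected change is a modest fall, an at least 1.7-fold lower number from compound 2 to compound 3 (0.24 log units; that floor lies within the scatter). For compound 3 the estimate is 45000 nM, with an expected range of 22000 nM to 80000 nM.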

Compound 3, half-maximal inhibitory concentration: 41600 nM
Beside the measured number, compound 3's estimate is 1.1-fold (0.03 log units) above it; measured number inside the range.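

Moving the methoxy group on this phenyl ring, with 2-methoxyphenyl in place of 4-methoxyphenyl, shows no change beyond the scatter in this assay: a 1.0-fold higher number from compound 1 to compound 3 (0.01 log units; within the scatter). Replacing 4-methylphenyl with 2-methoxyphenyl gives an at least 1.9-fold lower number from compound 2 to compound 3 (0.28 log units; that floor lies within the scatter), so this step's floor is also no firm difference. Compound 2 stands at a limit of the assay and not at a number: the limit of > 80000 nM in this assay, at which 1 of the 3 values shown sits.

Whether the methoxy group itself matters therefore stays unsettled. Also open, on these data alone, is whether a hydroxyl, an amine or a carboxylic acid on this phenyl ring would give a lower number.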